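A Methyl Group Added to Compound 2

The source may report more compounds than this note shows. Statements on the series, on what has been measured and on what is new or still open speak of the compounds shown alone.

Measured in a functional assay on WM1361 cells (Homo sapiens) for antiproliferative activity, read by MTT assay, with a stated time of 48 h; a lower number here means a stronger inhibitor, a higher number a weaker inhibitor:
- compound 1 `O=C(Nc1cc(-c2ccccc2)[nH]n1)c1cccnc1F`: 14600 nM
- compound 2 `O=C(Nc1cc(-c2ccccc2)[nH]n1)c1cncc(Br)c1`: 19300 nM
- compound 3 `O=C(Nc1cc(-c2ccccc2)[nH]n1)c1ccc(Cl)nc1`: 19000 nM

Compound 2, at 19300 nM, stands within the scatter of the other two compounds. Compound 4 `Cc1ccc(-c2cc(NC(=O)c3cncc(Br)c3)n[nH]2)cc1` carries methyl in place of hydrogen on an aromatic carbon, phenyl to 4-methylphenyl: methyl in place of hydrogen on an aromatic carbon.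

The measured steps all alter the group on the carbonyl carbon: a 1.3-fold higher number from compound 1 to compound 2 (0.12 log units; within the scatter), a 1.0-fold lower number from compound 2 to compound 3 (0.01 log units; within the scatter) and a 1.3-fold higher number from compound 1 to compound 3 (0.11 log units; within the scatter). None of them tests the new change directly, and all are small. No shift beyond the scatter is therefore expected in this assay. The expected step is a 1.1-fold lower number from compound 2 to compound 4 (0.06 log units; within the scatter). For compound 4 the estimated value is 17000 nM, with an expected range from 8000 nM to 35000 nM.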

Compound 4, half-maximal inhibitory concentration: 17900 nM
The estimate for compound 4 lay 1.1-fold (0.02 log units) below the measured number, within the range that was stated.
By their numbers in this assay, from the lowest: compounds 1, 4, 3 and 2 (each within the scatter of the next).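

Where the earlier compounds changed only the group on the carbonyl carbon, this step changes the far end of the molecule: in this assay, going from phenyl to 4-methylphenyl gives a 1.1-fold lower number from compound 2 to compound 4 (0.03 log units; within the scatter) and stays within the scatter. A methyl group on this aromatic carbon, para to a large group, therefore leaves the number essentially where it was. No available evidence bears on this result.

On these data alone, whether a carboxylic acid, an amine or a longer chain at this position would move the number beyond the scatter remains open. Also open, as far as these compounds go, is whether methyl behaves the same way when paired with the carbonyl groups of compound 1 or compound 3.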